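This account rests on a few compounds, and the source may have more. Where it says the series, first, only, none or still open, it means among the compounds named here.

Working notes on the series.

In a functional assay on CCRF-CEM cells (Homo sapiens) for inhibition, read by cell counting, with a stated time of 3 days (a higher number here means a weaker inhibitor, a lower number a stronger inhibitor), compound 3 `C=C(Br)C(=O)Nc1cccc(-c2cn3nc(-c4ccc(OC)c(OC)c4)sc3n2)c1` gives 380 nM, the lowest number of the three measured compounds. Compound 1 `C=C(Br)C(=O)Nc1cccc(-c2cn3nc(-c4ccc(F)cc4)sc3n2)c1` gives 830 nM in this assay, and compound 2 `C=C(Br)C(=O)Nc1cccc(-c2cn3nc(-c4ccc(C)cc4)sc3n2)c1` gives 1700 nM. The three steps are all modest: a 2.0-fold higher number from compound 1 to compound 2 (0.31 log units; beyond the scatter), a 2.2-fold lower number from compound 1 to compound 3 (0.34 log units; beyond the scatter) and a 4.5-fold lower number from compound 2 to compound 3 (0.65 log units; beyond the scatter). Every change so far has been a swap of substituents on the pendant aromatic ring, so the whole spread of this assay across the series is contained in these numbers.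

Compound 4 `C=C(Br)C(=O)Nc1cccc(-c2cn3nc(-c4cccs4)sc3n2)c1` takes a different kind of step from compound 3: thiophen-2-yl in place of 3,4-dimethoxyphenyl on an aromatic carbon. Among the measured compounds shown here, no measured pair exchanges the six-membered ring itself, so none of the steps above bears directly on it; they only show that changes at this position have moved this assay by modest amounts in either direction. Since compound 3 holds the lowest number, a drift back toward the numbers of compound 1 and compound 2 is the expectation, as a modest step of a 2.4-fold higher number from compound 3 to compound 4 (0.37 log units; beyond the scatter). Compound 4 is therefore estimated at 900 nM, with a range from 300 nM to 3000 nM.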

Compound 4, half-maximal inhibitory concentration: 410 nM
Estimate against measurement, compound 4: 2.2-fold (0.34 log units) above; the measured number falls inside the stated range.
By their numbers in this assay, from the lowest: compounds 3 and 4 (each within the scatter of the next); then compound 1; then compound 2.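

The result shows that a six-membered ring is not needed at this aromatic carbon for a number at the low end of the series: thiophen-2-yl in place of 3,4-dimethoxyphenyl gives a 1.1-fold higher number from compound 3 to compound 4 (0.03 log units; within the scatter) in this assay. The low number is therefore not confined to 3,4-dimethoxyphenyl, and the same thiophen-2-yl exchange gives a 4.1-fold lower number from compound 2 to compound 4 (0.62 log units; beyond the scatter) and a 2.0-fold lower number from compound 1 to compound 4 (0.31 log units; beyond the scatter), so both the methyl-bearing and the fluoro-bearing phenyl rings stand apart from these two groups. Nothing at hand explains why these groups group together in this way.

Open, as far as these compounds go, is whether an aromatic ring is needed here at all, since a morpholine, an amine or a short alkyl chain on this carbon would test that. Also open, from the compounds shown here alone, is whether furan-2-yl or thiophen-3-yl would track thiophen-2-yl.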